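Methoxy to Methyl on the Side Chain: Clearance Outlook

The source may hold more compounds than are shown below. What is called first, only, known or untested is meant among the compounds shown, and "the series" means these compounds.

Three compounds share a core and have been run in an ADME assay on liver for metabolic stability, with Liver microsome (Homo sapiens) as the target, read by LC-MS, using microsomes; a higher number here means faster removal of the compound, a lower number slower removal. Compound 1, `COC(C)(C)[C@@H](O)C(=O)N1[C@H](C(=O)NCc2cc(Cl)ccc2-n2cnnn2)C[C@@H]2C[C@@H]21`, gives 40 mL.min-1.g-1 and stands second highest of the three numbers. Compound 3, `O=C(NCc1cc(Cl)ccc1-n1cnnn1)[C@@H]1[C@H]2C[C@H]2CN1C(=O)[C@H](O)c1ccccc1`, gives 61 mL.min-1.g-1, a result that lies within the scatter of the value for compound 1. Compound 2, `O=C(NCc1cc(Cl)ccc1-n1cnnn1)[C@@H]1CC=NN1C(=O)[C@H](O)c1ccccc1F`, gives 16 mL.min-1.g-1, the lowest of the set and beyond the scatter from compound 1.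

Compound 4, `CC(C)(C)[C@@H](O)C(=O)N1[C@H](C(=O)NCc2cc(Cl)ccc2-n2cnnn2)C[C@@H]2C[C@@H]21`, is not yet measured. It differs from compound 1 by methyl in place of methoxy on a saturated chain carbon bound to three saturated chain carbons. Among the measured compounds shown here, no measured pair shows this change, so the step is expected to be small, with no direction beyond the scatter: a 1.1-fold lower number from compound 1 to compound 4 (0.06 log units; within the scatter). Compound 4 is therefore estimated at 35 mL.min-1.g-1 in this assay, with a range from 15 mL.min-1.g-1 to 80 mL.min-1.g-1.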

Compound 4, intrinsic clearance in microsomes: 75 mL.min-1.g-1
Compound 4: middle estimate off by 2.1-fold (0.33 log units), on the low side; the measured number falls inside the stated range.
By their numbers in this assay, from the lowest: compound 2; then compounds 1, 3 and 4 (each within the scatter of the next).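

Among the compounds shown here, compound 1 and compound 4 form the first pair that differs in one place, so this position can now be read directly: methyl in place of methoxy on a saturated chain carbon bound to three saturated chain carbons gives a 1.9-fold higher number from compound 1 to compound 4 (0.27 log units; within the scatter) in this assay here. Taken alone, this single pair does not separate 1-methoxy-1-methylethyl from tert-butyl. No measurement shown bears on why the pair reads as it does.

As far as these compounds go, how ethoxy or trifluoromethyl would read in this assay at this place remains open, as does whether this step carries over to another core.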